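The source may hold more compounds than are shown below. What is called first, only, known or untested is meant among the compounds shown, and "the series" means these compounds.

Measured in a functional assay on U-251 cells (Homo sapiens) for inhibition, read by MTT assay, with a stated time of 2 days; a lower number here means that less compound is tolerated, a higher number that more compound is tolerated:
- Compound 1 `Nc1ccccc1NC(=O)CCCNCC(=O)Nc1cccc(Cl)c1`: > 100000 nM
- Compound 2 `Nc1ccccc1NC(=O)CCCNCC(=O)Nc1cccc([N+](=O)[O-])c1`: > 100000 nM
- Compound 3 `Nc1ccccc1NC(=O)CCCNCC(=O)Nc1ccccc1Cl`: > 100000 nM

Each of these three entries is a limit and not a number. The series as measured so far sits entirely at the limit of > 100000 nM in this assay, at which 3 of the 3 values shown sit.

Compound 3 therefore has no exact position, and its > 100000 nM is a limit. The next compound, compound 4 `COc1ccc(NC(=O)CNCCCC(=O)Nc2ccccc2N)cc1`, differs from it on an amide-type nitrogen, where 4-methoxyphenyl takes the place of 2-chlorophenyl: 4-methoxyphenyl in place of 2-chlorophenyl on an amide-type nitrogen.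

Among the compounds with values here, three measured steps bear on this change. The two that alter the group on this nitrogen are a step that the two limits leave unreadable from compound 1 to compound 3 and a step that the two limits leave unreadable from compound 2 to compound 3. The third, a nitro in place of a chloro on an aromatic carbon, is a step that the two limits leave unreadable from compound 1 to compound 2. None of them provides a size, so they offer no measured effect to carry over, only the fact that all three compounds stop at the same limit.

No step beyond the scatter is expected in this assay, and no direction can be assigned. For the change to compound 4, the expected size is a number no higher from compound 3 to compound 4 (the limit leaves the size open). Compound 4 is estimated at 100000 nM, with an expected range from 50000 nM to 200000 nM.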

Compound 4, concentration lethal to 50% of the cells: > 100000 nM
Compound 4: a limit, no number; the forecaster's own chance of this, stated with the estimate: 80%; the middle value sits exactly at the limit.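

In this assay compound 4 gives > 100000 nM, which is a limit and not a number. No new step can therefore be read between compound 4 and compound 1, compound 2 or compound 3, and the series stays at one limit: the limit of > 100000 nM in this assay, at which 4 of the 4 values shown sit.

The compounds shown leave open the exact value of each compound and whether the group on the amide-type nitrogen makes any difference in this assay.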